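Cyclopropyl in Place of Ethyl on a Sulfur-Bound Chain

The source may report more compounds than this note shows. Statements on the series, on what has been measured and on what is new or still open speak of the compounds shown alone.

Measured compounds:
compound 1, `CCCSc1nc2nc(C)cc(N3CC[C@@H](C)[C@@H](N(C)c4ncnc5[nH]ccc45)C3)n2n1`: 51200 nM
compound 2, `C[C@@H]1CCN(c2cc(-c3ccccc3)nc3ncnn23)C[C@@H]1N(C)c1ncnc2[nH]ccc12`: > 100000 nM

For the measured compounds named here, in a functional assay on BGC-823 cells (Homo sapiens) for inhibition, read by MTT assay, with a stated time of 72 h (on this read-out lower numbers stand for stronger inhibition and higher numbers for weaker inhibition), compound 1 gives 51200 nM, and this is the only plain number among the two measured compounds. For compound 2 this assay reports only > 100000 nM, which is a limit of the assay and not a number. That limit is the limit of > 100000 nM in this assay, at which 1 of the 2 values shown sits. Going by the values given here, compound 1 therefore stands alone as the one compound with a measured number, and no step between two measured compounds is available to show how a single structural change shifts this assay.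

Compound 3, `Cc1cc(N2CC[C@@H](C)[C@@H](N(C)c3ncnc4[nH]ccc34)C2)n2nc(SCC3CC3)nc2n1`, has not yet been measured in this assay. It differs from compound 1 in one place: cyclopropyl in place of ethyl on a saturated chain carbon bound to a sulfur. Among the compounds with values here, with no measured step to lean on, the expectation rests on the smallness of this change alone. The step of a 1.1-fold lower number from compound 1 to compound 3 (0.06 log units; within the scatter) is expected to stay within the usual scatter of repeated measurements, with no clear direction. Compound 3 is therefore expected to give about 45000 nM in this assay, within a range from 15000 nM to 130000 nM.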

Compound 3, half-maximal inhibitory concentration: 36500 nM
Estimate against measurement, compound 3: 1.2-fold (0.09 log units) above; measured number inside the range.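

With compound 3, this series gains its first step between two measured compounds that differ in one place. In this assay, replacing ethyl with cyclopropyl on a saturated chain carbon bound to a sulfur gives a 1.4-fold lower number from compound 1 to compound 3 (0.15 log units; within the scatter) and so leaves the two compounds indistinguishable on this read-out, which shows that this position accepts a small carbon ring in place of an open ethyl end without a measurable change. The measurements shown give no basis for saying why this swap makes so little difference.

For the compounds shown here, this single step covers only two closely related carbon groups on the sulfur-bound chain, so it cannot show how far the position's tolerance extends, or whether a longer chain such as octyl, or a chain ending in an amine or a carboxylic acid, would move the number beyond the usual scatter. It also leaves open whether the same swap would behave alike on a compound with a different group elsewhere on the shared core, since this one comparison rests on a single pair.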